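Replacing the Isopropylamino Group with Methyl

The compounds below may be only part of what the source reports. "The series", "measured", "known", "first", "only" and "open" are said of these compounds alone.

Compound 1 `CCCNc1cc(Oc2ccc(NC(=O)Nc3cccc(C(F)(F)F)c3)cc2)ncn1` gives 32 nM in an assay on isolated protein for inhibition of serine/threonine-protein kinase TNNI3K (Homo sapiens); on this read-out lower numbers stand for stronger inhibition and higher numbers for weaker inhibition. Compound 2 `CC(C)Nc1cc(Oc2ccc(NC(=O)Nc3cccc(C(F)(F)F)c3)cc2)ncn1` gives 40 nM and stands as the higher of the two numbers measured, though a 1.3-fold higher number from compound 1 to compound 2 (0.10 log units; within the scatter) keeps it within the scatter of compound 1. Compound 3 `Cc1cc(Oc2ccc(NC(=O)Nc3cccc(C(F)(F)F)c3)cc2)ncn1` differs from compound 2 by methyl in place of isopropylamino on an aromatic carbon. Within the data shown here, the only measured step swapped one alkyl chain for another on the nitrogen and left the number essentially unchanged, so it bears weakly here, where the nitrogen itself leaves. Lacking a closer comparison, compound 3 is estimated at 150 nM (range 40 nM to 600 nM), an expected 3.8-fold higher number from compound 2 to compound 3 (0.57 log units; beyond the scatter).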

Compound 3, half-maximal inhibitory concentration: 160 nM
Compound 3: middle estimate off by 1.1-fold (0.03 log units), on the low side; the measured number falls inside the stated range.
By their numbers in this assay, from the lowest: compounds 1 and 2 (each within the scatter of the next); then compound 3.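

Changing the chain on the nitrogen mattered little, but removing the whole alkylamino group does matter at this position: in this assay, methyl gives a 4.0-fold higher number from compound 2 to compound 3 (0.60 log units; beyond the scatter) and, against the propylamino group, a 5.0-fold higher number from compound 1 to compound 3 (0.70 log units; beyond the scatter). Both steps run the same way, yet the nitrogen and its carbons leave together, so their shares cannot be separated. Nothing on hand explains the change.

Still open, from the compounds shown here alone, is whether the nitrogen or the carbon chain carries the difference. A plain amino group or an ethyl group in this place would test that.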